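The source may report more compounds than this note shows. Statements on the series, on what has been measured and on what is new or still open speak of the compounds shown alone.

Compound 3 `Cc1cc(Sc2ccc(Cl)cc2)c(S(C)(=O)=O)cc1C(=O)N=C(N)N` gives 19 nM in a functional assay for inhibition of sodium/hydrogen exchanger (Oryctolagus cuniculus) (a lower number here means a stronger inhibitor, a higher number a weaker inhibitor), and stands level with compound 2 `Cc1cc(-c2ccccc2)c(S(C)(=O)=O)cc1C(=O)N=C(N)N`, which gives 19 nM, the two together at the low end of the three numbers; compound 1 `CCN(CC)Cc1cc(Br)c(S(C)(=O)=O)cc1C(=O)N=C(N)N`, which gives 9500 nM, lies far higher. The step of no change at the digits printed from compound 2 to compound 3 (within the scatter) shows that the aromatic carbon ortho to the methylsulfonyl group accepts either ring without a shift in the number. Compound 4 `Cc1cn(-c2cc(C)c(C(=O)N=C(N)N)cc2S(C)(=O)=O)cn1` carries the change (4-methyl-1H-imidazol-1-yl in place of (4-chlorophenyl)sulfanyl on an aromatic carbon). Among the measured compounds shown here, only that one step bears on the new compound, and it was flat; the five-membered ring with two hetero atoms is smaller than either group seen so far, so a modest weakening is expected, within or just beyond the scatter, as a 2.1-fold higher number from compound 3 to compound 4 (0.32 log units; beyond the scatter). Compound 4 is therefore expected to give about 40 nM in this assay, with a range from 10 nM to 200 nM.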

Compound 4, half-maximal inhibitory concentration: 28 nM
Compound 4: the middle estimate sits 1.4-fold (0.15 log units) above what was measured, and the stated range covers the measured number.
By their numbers in this assay, from the lowest: compounds 2, 3 and 4 (each within the scatter of the next); then compound 1.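

In this assay, the aromatic carbon ortho to the methylsulfonyl group also accepts a five-membered aromatic ring with 2 hetero atoms, with a 1.5-fold higher number from compound 3 to compound 4 (0.17 log units; within the scatter) and a 1.5-fold higher number from compound 2 to compound 4 (0.17 log units; within the scatter) both showing that the swap leaves the number within the scatter. The earlier compounds had shown only six-membered aromatic rings of carbon at this place, so the tolerance now extends to 4-methyl-1H-imidazol-1-yl, which has 2 hydrogen-bond acceptors and 6 heavy atoms against the 8 heavy atoms of (4-chlorophenyl)sulfanyl. No measurement here accounts for this flat result.

From the compounds shown here alone, whether this carbon would tolerate a group without a ring, such as a simple amine or a carboxylic acid, remains open. Compound 1 differs from the others in more than one place, so it does not settle what a bromine alone would do here.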